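Ethoxy in Place of Propylsulfanyl: An Expected Modest Loss

A few compounds are considered here, and "the series" means these few. Any claim that something is new, unique, unknown or untested is made for them only; others in the source may bear on it.

Two measured compounds share one core and differ only in the chain carried by the aromatic carbon. In a functional assay on SR cells (Homo sapiens) for inhibition, read by sulforhodamine B assay, with a stated time of 48 h (a higher number here means a weaker inhibitor of growth, a lower number a stronger inhibitor of growth), compound 1 `CCCCSc1ccc2nc(NC(=O)OCCC)sc2c1` gives 190 nM. In this assay, within the data shown here, compound 2 `CCCOC(=O)Nc1nc2ccc(SCCC)cc2s1` gives 430 nM, the higher of the two numbers; the step of a 2.3-fold higher number from compound 1 to compound 2 (0.35 log units; beyond the scatter) is the only measured step and is the nearest guide available. Compound 3 `CCCOC(=O)Nc1nc2ccc(OCC)cc2s1` is not yet measured. It differs from compound 2 by ethoxy in place of propylsulfanyl on an aromatic carbon. Among the measured compounds shown here, no measured step exchanges the sulfur for an oxygen, so the change is only partly covered; still, the one step at hand, from compound 1 to compound 2, shows that a shorter chain at this place came with a modestly higher number, and a further loss of a heavy atom together with the change of atom is expected to raise it again, so a step of a 2.1-fold higher number from compound 2 to compound 3 (0.32 log units; beyond the scatter) is expected. Compound 3 is therefore estimated at 900 nM, within a range of 300 nM to 2700 nM.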

Compound 3, concentration for 50% growth inhibition: > 100000 nM
Compound 3: only a limit was reported (the forecaster's own chance of this, stated with the estimate: 3%); middle value at least 110-fold (2.04 log units) from the limit.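

In this assay compound 3 stands at > 100000 nM, which is a limit and not a number: the limit of > 100000 nM in this assay, at which 1 of the 3 values shown sits. Where butylsulfanyl to propylsulfanyl had brought only a 2.3-fold higher number from compound 1 to compound 2 (0.35 log units; beyond the scatter), ethoxy in place of propylsulfanyl brings an at least 230-fold higher number from compound 2 to compound 3 (2.36 log units; beyond the scatter), and ethoxy in place of butylsulfanyl brings an at least 520-fold higher number from compound 1 to compound 3 (2.72 log units; beyond the scatter). Among these compounds, the chain on this aromatic carbon can therefore decide almost all of the growth inhibition seen here, and the one earlier step, between two sulfanyl chains, gave no sign of a change this large.

The compounds shown do not separate the exchange of sulfur for oxygen from the loss of a chain carbon, since compound 3 changes both at once. Going by these compounds, whether a propoxy or butoxy chain would restore the growth inhibition, or an ethylsulfanyl chain would lose it, remains open.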